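Sulfonyl Analogue Series: Trifluoromethyl Replaced by Fluoro

The compounds below may be only part of what the source reports. "The series", "measured", "known", "first", "only" and "open" are said of these compounds alone.

Of the compounds shown here, three have been measured in a functional assay on HepG2 cells (Homo sapiens) for cytotoxicity, read by MTT assay, with a stated time of 24 h; on this read-out lower numbers stand for stronger inhibition and higher numbers for weaker inhibition. Compound 1 `CN1C/C(=C\c2ccncc2)C(=O)/C(=C/c2ccccc2F)C1` gives 4600 nM. Compound 2 `CN1C/C(=C\c2ccncc2)C(=O)/C(=C/c2ccccc2C(F)(F)F)C1` gives 3300 nM, and compound 3 `O=C1/C(=C/c2cccnc2)CN(S(=O)(=O)c2ccc(C(F)(F)F)cc2)C/C1=C\c1ccccc1C(F)(F)F` gives 1710 nM. The step of a 1.4-fold higher number from compound 2 to compound 1 (0.14 log units; within the scatter) belongs to the change (fluoro in place of trifluoromethyl on an aromatic carbon). Compound 3 and compound 2 differ in more than one place; how their cores differ is not broken down here. Compound 4 `O=C1/C(=C/c2cccnc2)CN(S(=O)(=O)c2ccc(F)cc2)C/C1=C\c1ccccc1C(F)(F)F` has not yet been measured; it differs from compound 3 by fluoro in place of trifluoromethyl on an aromatic carbon. This is the same kind of change as that from compound 2 to compound 1, but the surroundings differ: there the group sits ortho to a large group, here para to a large group. Beside the earlier step, the step of a 1.3-fold higher number from compound 3 to compound 4 (0.13 log units; within the scatter) is expected to be of similar size, because a 1.4-fold higher number from compound 2 to compound 1 (0.14 log units; within the scatter) lay within the scatter. Compound 4 is therefore estimated at 2300 nM, with a range from 1000 nM to 5500 nM.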

Compound 4, half-maximal inhibitory concentration: 2340 nM
Beside the measured number, compound 4's estimate is 1.0-fold (0.01 log units) below it, within the range that was stated.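

In this assay the exchange of trifluoromethyl for fluoro gives a 1.4-fold higher number from compound 3 to compound 4 (0.14 log units; within the scatter) and thus matches the step on the other core: the same change on two cores in this assay, a 1.4-fold higher number (0.14 log units; within the scatter) from compound 2 to compound 1 and a 1.4-fold higher number (0.14 log units; within the scatter) from compound 3 to compound 4, 1.0-fold (0.01 log units) apart, within the scatter of two such steps. On these two cores, the change carries over as a step that stays within the scatter. This does not show a measurable effect of the change on either core, and two cores cannot establish a rule for the whole series.

The compounds shown leave open whether a nitrile or a methoxy group at the same place would give a step beyond the scatter. They also leave open whether the exchange of trifluoromethyl for fluoro would behave alike on a core carrying an amine.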